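Adding an amino group to compound 2

A few compounds are considered here, and "the series" means these few. Any claim that something is new, unique, unknown or untested is made for them only; others in the source may bear on it.

Values measured so far in a functional assay on U-87MG ATCC cells (Homo sapiens) for antiproliferative activity; a lower number here means a stronger inhibitor, a higher number a weaker inhibitor:
- compound 1 `CC(=O)N1CCCc2c(C)c3c(n2-c2ccc(C(N)=O)c(c2)N[C@@H](C)[C@@H]1C)CC(C)(C)CC3=O` gives 29 nM
- compound 2 `CC(=O)N1CCc2c(C)c3c(n2-c2ccc(C(N)=O)c(c2)N[C@@H](C)[C@H](C)C1)CC(C)(C)CC3=O` gives 24 nM
- compound 3 `Cc1c2c(n3c1CCCN(C(=O)CN)[C@@H](C)[C@H](C)Nc1cc-3ccc1C(N)=O)CC(C)(C)CC2=O` gives 481 nM

Compound 2 sits with compound 1 at the low end of these numbers, the two lying within the scatter of each other, while compound 3 reads far higher. Compound 4 `Cc1c2c(n3c1CCN(C(=O)CN)C[C@@H](C)[C@H](C)Nc1cc-3ccc1C(N)=O)CC(C)(C)CC2=O` is compound 2 with amino in place of hydrogen on a saturated chain carbon bound to a carbonyl carbon. Among the compounds with values here, only one measured step shows this same change, a 17-fold higher number from compound 1 to compound 3 (1.22 log units; beyond the scatter), which is large and beyond the scatter. A rise of similar size is therefore expected in this assay, though the core of compound 2 is not that of compound 1. The expected step is a 17-fold higher number from compound 2 to compound 4 (1.22 log units; beyond the scatter), an estimate resting on that single pair. Compound 4 is estimated at 400 nM, with an expected range of 150 nM to 1000 nM.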

Compound 4, half-maximal inhibitory concentration: 378 nM
Compound 4: middle estimate off by 1.1-fold (0.02 log units), on the high side; the measured number falls inside the stated range.
By their numbers in this assay, from the lowest: compounds 2 and 1 (each within the scatter of the next); then compounds 4 and 3 (each within the scatter of the next).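

In this assay, amino in place of hydrogen on a saturated chain carbon bound to a carbonyl carbon gives a 16-fold higher number from compound 2 to compound 4 (1.20 log units; beyond the scatter), so the rise in the number is no longer confined to a single core. The size of the change also holds from one core to the other: the same change on two cores in this assay, a 17-fold higher number (1.22 log units; beyond the scatter) from compound 1 to compound 3 and a 16-fold higher number (1.20 log units; beyond the scatter) from compound 2 to compound 4, 1.1-fold (0.02 log units) apart, within the scatter of two such steps

The compounds shown carry only acetyl and (aminomethyl)carbonyl at this place, so they leave open how a longer chain bearing the amine or a carboxylic acid in place of the amino would read. They also cannot tell whether a dimethylamino group would give a step of the same size.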